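Pyrazoline series: chloro to 4-hydroxypiperidin-1-yl on the carbonyl chain

This account rests on a few compounds, and the source may have more. Where it says the series, first, only, none or still open, it means among the compounds named here.

Two compounds have numbers in a functional assay on MGC-803 cells (Homo sapiens) for cytotoxicity, read by MTT assay, with a stated time of 48 h; on this read-out lower numbers stand for stronger inhibition and higher numbers for weaker inhibition. Compound 1 `CC1=NN(C(=O)c2ccc(C)cc2)C(c2cc(Br)ccc2O)C1` gives 21000 nM in this assay. Compound 2 `O=C(CCl)N1N=C(c2cc3ccccc3oc2=O)CC1c1ccccc1`, with a different core, gives 2020 nM and holds the lowest of the two numbers; compound 1 stands a whole order higher, a gap beyond the scatter. Among the measured compounds shown here, no pair of measured compounds differs in a single place, so no measured step is available to lean on.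

Compound 3 `O=C(CN1CCC(O)CC1)N1N=C(c2cc3ccccc3oc2=O)CC1c1ccccc1` is the next compound. Its change from compound 2 is 4-hydroxypiperidin-1-yl in place of chloro on a saturated chain carbon bound to a carbonyl carbon. For the measured compounds named here, no measured step involves this chain position, and the series gives no reading on what such a replacement does here. Without a measured anchor, the expected step from compound 2 in this assay is small, at most a modest rise in the number, so a 1.7-fold higher number from compound 2 to compound 3 (0.24 log units; within the scatter) is the estimate of that step. Compound 3 is expected to give about 3500 nM in this assay, within a range from 1000 nM to 12000 nM.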

Compound 3, half-maximal inhibitory concentration: "not active" (no number reported)
Nothing numeric was reported for compound 3, and the estimate cannot be compared.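

Among the compounds shown here, compound 3 is reported only as "not active" in this assay, with no number, and no step from compound 2 to compound 3 can be read. Nothing shown bears on this result. The compounds shown leave open how other groups in place of chloro on this chain carbon would read.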